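A few compounds are considered here, and "the series" means these few. Any claim that something is new, unique, unknown or untested is made for them only; others in the source may bear on it.

Working notes on the series.

Going by the values given here, compound 1 `O=C(Nc1ccc(Oc2cc(C(F)(F)F)cc(C(F)(F)F)c2)cc1)c1ccccc1F` is the one member of this set with a number: in an assay on HEK293 cells for inhibition of Toll-like receptor 8 (Homo sapiens), with a stated time of 16 h (on this read-out lower numbers stand for stronger inhibition and higher numbers for weaker inhibition), compound 1 gives 3000 nM. Among the compounds with values here, compound 2 `O=C(Nc1ccc(Oc2cc(C(F)(F)F)cc(C(F)(F)F)c2)cc1)c1c(F)cccc1C(F)(F)F` shares the core of compound 1 and differs only in the group on the carbonyl carbon, but in this assay compound 2 is recorded as "not determined" (no result reported), so it stands on no number at all and no step from compound 1 to compound 2 can be read. Compound 3 `Nc1ccc(C(=O)Nc2ccc(Oc3cc(C(F)(F)F)cc(C(F)(F)F)c3)cc2)c(F)c1` is not yet measured. The change from compound 2 to compound 3 is 4-amino-2-fluorophenyl in place of 2-fluoro-6-(trifluoromethyl)phenyl on a carbonyl carbon. Within the data shown here, with no value for compound 2 and no step between measured compounds, the size of this step in this assay cannot be read from the data; only compound 1, whose value 3000 nM is the sole anchor, gives any point of reference for a benzamide of this kind. On that basis compound 3 is expected to land in the same general region as compound 1, with no clear direction beyond the scatter. The estimate for compound 3 in this assay is 2500 nM, within a range of 600 nM to 10000 nM.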

Compound 3, half-maximal inhibitory concentration: > 50000 nM
Compound 3 gave a limit, no number (the forecaster's own chance of this, stated with the estimate: 20%); middle value at least 20-fold (1.30 log units) away from the limit.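

Working from the one readable pair, amino in place of hydrogen on an aromatic carbon, within the group on the carbonyl carbon, gives an at least 16-fold higher number from compound 1 to compound 3 (1.22 log units; beyond the scatter) in this assay, so this single change is enough to move the read-out well past the scatter towards weaker inhibition. The entry for compound 3 is a limit of the assay and not a number, so the step has a lower bound but no measured size: the limit of > 50000 nM in this assay, at which 1 of the 3 values shown sits. Compound 1 alone could not show that this part of the molecule responds so strongly to one added group, though the claim rests on this one pair, and the steps that involve compound 2 cannot be read.

Whether the loss belongs to the amino group itself stays open, since no hydroxyl, methoxy, acetylamino or dimethylamino group stands in its place among the compounds shown. Also open, from the compounds shown here alone, is how a 2-fluoro-6-(trifluoromethyl)phenyl group on the carbonyl carbon compares with either neighbour in this assay, since compound 2 carries no value.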